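From an Ethyl Ester to an Aminoethyl Amide

The compounds below may be only part of what the source reports. "The series", "measured", "known", "first", "only" and "open" are said of these compounds alone.

Compound 1 `CCOC(=O)c1c(O)c2cccnc2n(-c2ccccc2)c1=O` stands highest of the three measured compounds in a functional assay on the whole organism for inhibition, with Rattus norvegicus as the target, read by paw edema, at a dose of 100 mg/kg by the oral route (on this read-out higher numbers stand for more inhibition at the one dose given (going by the name of the read-out) and lower numbers for less inhibition), where compound 1 gives 23.5%. Compound 2 `O=C(Nc1ccccn1)c1c(O)c2cccnc2n(-c2ccccc2)c1=O` gives -13.5%, and compound 3 `CCCCNC(=O)c1c(O)c2cccnc2n(-c2ccccc2)c1=O` gives 12.8%. The change leading to compound 4 `CN(C)CCNC(=O)c1c(O)c2cccnc2n(-c2ccccc2)c1=O` is (2-(dimethylamino)ethyl)amino in place of ethoxy on a carbonyl carbon. Among the compounds with values here, two measured steps bear on this, since each also replaces ethoxy on the carbonyl carbon with an amino group: a number 37 percentage points lower from compound 1 to compound 2 (beyond the scatter) and a number 10.7 percentage points lower from compound 1 to compound 3 (beyond the scatter). Both point downward, one large and one modest, so a drop beyond the scatter is expected for compound 4, most likely lying between those two. The expected step is a number 19.5 percentage points lower from compound 1 to compound 4 (beyond the scatter). Compound 4 is therefore estimated at 4%, with a range from -18% to 24%.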

Compound 4, a percentage reported as inhibition, in the whole organism at one dose (the size of the read-out at that dose, not a potency): 22.6%
Estimate against measurement, compound 4: 18.6 percentage points below, and the stated range covers the measured number.
By their numbers in this assay, from the lowest: compound 2; then compounds 3, 4 and 1 (each within the scatter of the next, the first and the last beyond it).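

In this assay, the step of a number 0.9 percentage points lower from compound 1 to compound 4 (within the scatter) shows that an amide on this carbonyl carbon can match the ethoxy ester. The group on the amide nitrogen still matters: the step of a number 36.1 percentage points higher from compound 2 to compound 4 (beyond the scatter) follows from 2-(dimethylamino)ethyl replacing pyridin-2-yl, while the step of a number 9.8 percentage points higher from compound 3 to compound 4 (within the scatter) separates the dimethylamino chain from the butyl chain by no more than the usual scatter. Nothing available explains these differences.

Still open, on these data alone, is whether a longer chain, such as 3-(dimethylamino)propyl, or morpholine at the chain end would give a similar number. A carboxylic acid in place of the ester is also an open case.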